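Removing One Fluorine from a Chalcone-Type Antiproliferative Series

A few compounds are considered here, and "the series" means these few. Any claim that something is new, unique, unknown or untested is made for them only; others in the source may bear on it.

Compound 1 `O=C(COc1ccc(C(=O)/C=C/c2ccccc2Cl)cc1)N[C@H]1CCOC1=O`: 3240 nM
Compound 2 `O=C(COc1ccc(C(=O)/C=C/c2ccc(F)c(F)c2)cc1)N[C@H]1CCOC1=O`: 19800 nM
Compound 3 `O=C1OCC[C@@H]1NC(=S)SCCOc1cccc2ccccc12`: > 64000 nM

In a functional assay on DU-145 cells (Homo sapiens) for antiproliferative activity, read by MTT assay, with a stated time of 72 h (on this read-out lower numbers stand for stronger inhibition and higher numbers for weaker inhibition), compound 2 gives 19800 nM, the higher of the two numbers recorded, while compound 1 gives 3240 nM. For compound 3 only a limit was reached, namely > 64000 nM (the limit of > 64000 nM in this assay, at which 1 of the 3 values shown sits).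

Compound 4 `O=C(COc1ccc(C(=O)/C=C/c2ccc(F)cc2)cc1)N[C@H]1CCOC1=O` differs from compound 2 by hydrogen in place of fluoro on an aromatic carbon. Going by the values given here, the one measured step that concerns this part of the molecule is a 6.1-fold higher number from compound 1 to compound 2 (0.79 log units; beyond the scatter), a modest shift from exchanging one substituted phenyl for another. Taking away a single fluoro is a smaller alteration, so from compound 2 to compound 4 a step of a 2.0-fold lower number from compound 2 to compound 4 (0.30 log units; within the scatter) is expected, toward a somewhat lower number, close to the scatter. Compound 4 is therefore estimated at 10000 nM, between 3500 nM and 30000 nM.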

Compound 4, half-maximal inhibitory concentration: 18800 nM
The estimate for compound 4 lay 1.9-fold (0.27 log units) below the measured number; measured number inside the range.
By their numbers in this assay, from the lowest: compound 1; then compounds 4 and 2 (each within the scatter of the next). At a limit, above all of these: compound 3.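

A step of a 1.1-fold lower number from compound 2 to compound 4 (0.02 log units; within the scatter) in this assay lies within the scatter, so the fluoro on this aromatic carbon can go without a measurable change, and the 3,4-difluorophenyl and 4-fluorophenyl compounds cannot be told apart. The step of a 5.8-fold higher number from compound 1 to compound 4 (0.76 log units; beyond the scatter) lies beyond the scatter, so the gap to the 2-chlorophenyl compound remains with one fluoro as with two. Nothing measured here offers a reason for either result.

Going by these compounds, whether a methoxy group or an amine on this aromatic carbon would shift the number remains open. So does whether a plain phenyl, with no fluoro at all, would read like compound 4.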